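From 4-chlorophenyl to 2-chlorophenyl: an untested isomer

The source may hold more compounds than are shown below. What is called first, only, known or untested is meant among the compounds shown, and "the series" means these compounds.

Measured in a functional assay on A549 cells (Homo sapiens) for inhibition, read by MTT assay, with a stated time of 72 h; a lower number here means a stronger inhibitor, a higher number a weaker inhibitor:
compound 1 `CC(C)(C)n1cc2c(n1)C(=O)CC1(CCN(C(=O)c3cc(-c4ccccc4)nc4ccccc34)CC1)O2`: 1940 nM
compound 2 `Cc1ccc(-c2cc(C(=O)N3CCC4(CC3)CC(=O)c3nn(C(C)(C)C)cc3O4)c3ccccc3n2)cc1`: 5300 nM
compound 3 `CC(C)(C)n1cc2c(n1)C(=O)CC1(CCN(C(=O)c3cc(-c4ccc(Cl)cc4)nc4ccccc34)CC1)O2`: 2330 nM

Compound 3 lies within the scatter of compound 1 but stands apart from compound 2, shown by a 2.3-fold lower number from compound 2 to compound 3 (0.36 log units; beyond the scatter). Compound 4 `CC(C)(C)n1cc2c(n1)C(=O)CC1(CCN(C(=O)c3cc(-c4ccccc4Cl)nc4ccccc34)CC1)O2` has the same atoms joined differently: 2-chlorophenyl in place of 4-chlorophenyl on an aromatic carbon. Here 2-chlorophenyl replaces 4-chlorophenyl on an aromatic carbon next to the ring nitrogen. For the measured compounds named here, two measured steps bear on this change: a 1.2-fold higher number from compound 1 to compound 3 (0.08 log units; within the scatter) for chloro and a 2.7-fold higher number from compound 1 to compound 2 (0.44 log units; beyond the scatter) for methyl. Going by the values given here, no measured compound carries 2-chlorophenyl, so these steps guide the expectation only indirectly. Neither step is large, so no change beyond the scatter is expected in this assay. The expected step is a 1.1-fold higher number from compound 3 to compound 4 (0.05 log units; within the scatter). Compound 4 is estimated at 2600 nM, with an expected range of 1200 nM to 5600 nM.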

Compound 4, half-maximal inhibitory concentration: 2180 nM
Beside the measured number, compound 4's estimate is 1.2-fold (0.08 log units) above it; measured number inside the range.
By their numbers in this assay, from the lowest: compounds 1, 4 and 3 (each within the scatter of the next); then compound 2.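

In this assay, the place of the chlorine on the phenyl ring makes no difference beyond the scatter, with a 1.1-fold lower number from compound 3 to compound 4 (0.03 log units; within the scatter), and 2-chlorophenyl also stands within the scatter of plain phenyl, with a 1.1-fold higher number from compound 1 to compound 4 (0.05 log units; within the scatter). Compound 2 stays apart from this chlorophenyl isomer too, with a 2.4-fold lower number from compound 2 to compound 4 (0.39 log units; beyond the scatter), so 4-methylphenyl alone separates from the other three groups. No measurement shown here accounts for these numbers. From the compounds shown here alone, whether an amine or a carboxylic acid on that phenyl ring would shift the number beyond the scatter remains open.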